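A few compounds are considered here, and "the series" means these few. Any claim that something is new, unique, unknown or untested is made for them only; others in the source may bear on it.

Of the compounds shown here, three have been measured in a functional assay on cells (Cancer cell lines, Homo sapiens) for cytotoxicity, read by sulforhodamine B assay, with a stated time of 48 h; a lower number here means a stronger inhibitor of growth, a higher number a weaker inhibitor of growth. Compound 2 `O=C1N=C(N2N=C(c3ccccc3)CC2c2ccc(Cl)cc2)S/C1=C1/C(=O)Nc2ccccc21` gives 230 nM, the lowest of the three numbers. Compound 3 `Cc1ccc2c(c1)/C(=C1\SC(N3N=C(c4ccccc4)CC3c3ccc(Cl)cc3)=NC1=O)C(=O)N2`, which carries a methyl in place of hydrogen on an aromatic carbon, gives 260 nM, and the step of a 1.1-fold higher number from compound 2 to compound 3 (0.05 log units; within the scatter) lies within the scatter. Compound 1 `COc1ccc(C2=NN(C3=NC(=O)/C(=C4\C(=O)Nc5ccccc54)S3)C(c3ccc(OC)cc3)C2)cc1` gives 92200 nM, far from compound 2; it differs from compound 2 in two places, so the two values alone show that the pair of methoxy groups goes with a much weaker inhibitor, without telling which of the two carries the loss.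

Compound 4 `COc1ccc(C2=NN(C3=NC(=O)/C(=C4\C(=O)Nc5ccccc54)S3)C(c3ccc(Cl)cc3)C2)cc1` has not yet been measured in this assay. It differs from compound 2 by methoxy in place of hydrogen on an aromatic carbon. Among the compounds with values here, no measured step isolates this change. Within the data shown here, the only single-point step, from compound 2 to compound 3, concerns a methyl elsewhere and stayed within the scatter, so it gives no guide to the direction here. On these data alone, because compound 1 with both methoxy groups gives 92200 nM, a rise of some size is expected for compound 4, a 13-fold higher number from compound 2 to compound 4 (1.12 log units; beyond the scatter), though how much of that loss belongs to this one change alone is unknown. Compound 4 is therefore estimated at 3000 nM, with a range from 400 nM to 30000 nM.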

Compound 4, concentration for 50% growth inhibition: 100000 nM
The estimate for compound 4 lay 33-fold (1.52 log units) below the measured number, outside the stated range (above it).
By their numbers in this assay, from the lowest: compounds 2 and 3 (each within the scatter of the next); then compounds 1 and 4 (each within the scatter of the next).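

In this assay, within the data shown here, the loss left unassigned by the earlier compounds now has a place: phenyl to 4-methoxyphenyl, with methoxy in place of hydrogen on an aromatic carbon para to a large group, is by itself enough to give a 430-fold higher number from compound 2 to compound 4 (2.64 log units; beyond the scatter) and is a large step. The other methoxy group shows no separate effect once this one is present, since chloro in place of methoxy on an aromatic carbon gives a 1.1-fold higher number from compound 1 to compound 4 (0.04 log units; within the scatter) and the two compounds cannot be told apart in this assay. The data shown offer no explanation for the size of the methoxy step.

On these data alone, what remains open is whether this loss belongs to methoxy in particular or would follow any group at this place, which a hydroxyl, an amine or a longer chain such as ethoxy there would help to settle. As far as these compounds go, it also remains open whether chloro and methoxy at the other place would stay level on a compound that keeps the plain phenyl of compound 2, where any difference between them would not be hidden by the methoxy at this place.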